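The compounds below may be only part of what the source reports. "The series", "measured", "known", "first", "only" and "open" are said of these compounds alone.

Compound 1 `C#CCn1nnc2c(C(N)=O)ncn2c1=O`: 35600 nM
Compound 2 `NC(=O)c1ncn2c(=O)n(Cc3ccccc3)nnc12`: > 50000 nM
Compound 3 `COc1cccc(Cn2nnc3c(C(N)=O)ncn3c2=O)c1`: > 50000 nM

These values come from a functional assay on SNB-19 cells (Homo sapiens) for inhibition, read by MTT assay, with a stated time of 7 days; a higher number here means a weaker inhibitor of growth, a lower number a stronger inhibitor of growth. Compound 2 stands at > 50000 nM, which is a limit and not a number. Compound 3 gives > 50000 nM, also a limit. Two of the three compounds therefore share one ceiling: the limit of > 50000 nM in this assay, at which 2 of the 3 values shown sit.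

Compound 4 `Cc1cc(Cn2nnc3c(C(N)=O)ncn3c2=O)on1` differs from compound 2 as follows: 3-methyl-1,2-oxazol-5-yl in place of phenyl on a saturated chain carbon bound to an aromatic nitrogen. Among the measured compounds shown here, two measured steps bear on this. One shows an at least 1.4-fold higher number from compound 1 to compound 2 (0.14 log units; that floor lies within the scatter), a change at the same place, on a saturated chain carbon bound to an aromatic nitrogen. The other shows a step that the two limits leave unreadable from compound 2 to compound 3, a change on an aromatic carbon. Neither supports an expected shift beyond the scatter in this assay, in either direction. The expected change is a number no higher from compound 2 to compound 4 (the limit leaves the size open). Compound 4 is estimated at 50000 nM, with an expected range from 28000 nM to 90000 nM.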

Compound 4, concentration for 50% growth inhibition: > 50000 nM
Compound 4: only a limit was reported (the forecaster's own chance of this, stated with the estimate: 60%); the middle value sits exactly at the limit.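

Placing 3-methyl-1,2-oxazol-5-yl, with its hydrogen-bond acceptors, where phenyl stood still leaves a limit rather than a number, and compound 4 joins the same ceiling as compound 2 and compound 3: the limit of > 50000 nM in this assay, at which 3 of the 4 values shown sit. Steps between these limits cannot be read. Among the compounds shown here, the one readable comparison is an at least 1.4-fold higher number from compound 1 to compound 4 (0.14 log units; that floor lies within the scatter).

On these data alone, how far compound 2, compound 3 and compound 4 lie beyond the limit stays open. So does whether an amine, a carboxylic acid or a longer chain at this place would give a measurable value.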